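Replacing an Acetyl Methyl with a Larger Amide Group

The source may report more compounds than this note shows. Statements on the series, on what has been measured and on what is new or still open speak of the compounds shown alone.

Of the compounds shown here, two have been measured in a physicochemical assay for solubility, read by HPLC, in phosphate buffer, measured as kinetic solubility, at pH 7.4; on this read-out lower numbers stand for lower solubility and higher numbers for higher solubility. Compound 1 `CCC(=O)c1cc(-c2ccccc2)n(-c2ccc(S(N)(=O)=O)cc2)c1C` gives 14100 nM. Compound 2 `CC(=O)c1cc(-c2ccc(S(N)(=O)=O)cc2)n(-c2ccc(Cl)cc2)n1` gives 86800 nM, the higher of the two numbers, and the gap to compound 1 lies beyond the usual scatter. Going by the values given here, these two compounds differ in several places at once, so no single step between them can be read off.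

Compound 3 `CN(C(=O)c1cc(-c2ccc(S(N)(=O)=O)cc2)n(-c2ccc(Cl)cc2)n1)C1CC(F)(F)C1` is built from compound 2 by one change ((3,3-difluorocyclobutyl)(methyl)amino in place of methyl on a carbonyl carbon). Among the compounds with values here, nothing among the measured compounds shows what such a change does in this assay; the expectation below therefore rests on the size of the added group alone. A downward step is expected, a 4.3-fold lower number from compound 2 to compound 3 (0.64 log units; beyond the scatter), probably beyond the scatter. Compound 3 is estimated to give 20000 nM, with a plausible range from 5000 nM to 60000 nM.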

Compound 3, solubility: 30900 nM
Estimate against measurement, compound 3: 1.5-fold (0.19 log units) below; low and high end bracket the measured number.
By their numbers in this assay, from the lowest: compound 1; then compound 3; then compound 2.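

Going by these compounds alone, at the carbonyl carbon of compound 2, putting (3,3-difluorocyclobutyl)(methyl)amino in place of methyl gives a 2.8-fold lower number from compound 2 to compound 3 (0.45 log units; beyond the scatter) in this assay, the first step here that can be read at a single position. The acetyl thus becomes a much larger (3,3-difluorocyclobutyl)(methyl)carbamoyl group, and the cost in this read-out is only modest, with compound 3 still reading 30900 nM in this assay. Nothing among the data shown explains the direction or size of this step.

Going by these compounds, with a single change at this position, it remains open whether the drop belongs to the amide link or to the fluorinated ring. A dimethylamino group or a plain cyclobutyl(methyl)amino group on the same carbonyl carbon would separate these two, and a carboxylic acid there would show how far the number can move in the other direction.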